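The compounds below may be only part of what the source reports. "The series", "measured", "known", "first", "only" and "open" are said of these compounds alone.

Measured in an ADME assay on MT4 cells (Homo sapiens) for cytotoxicity, read by MTT assay, with a stated time of 96 h; on this read-out lower numbers stand for higher toxicity in this test and higher numbers for lower toxicity in this test:
compound 1 `Cc1cc(=O)oc2c(CN3CCc4ccccc4C3)c(O)ccc12`: > 100000 nM, a limit of the test and not a number
compound 2 `CCN(CC)c1oc2cc(OC(C)=O)ccc2c(=O)c1Cc1c(OC(C)=O)ccc2c(C)cc(=O)oc12`: 44000 nM

Compound 1 stands at the top edge of the numbers shown: its reading in this assay is a limit, not a figure, and it sits at the limit of > 100000 nM in this assay, at which 1 of the 2 values shown sits. Of the two measured compounds only the larger compound 2 gives an actual number, 44000 nM in this assay. The two differ in more than one place, so their values are set side by side without a computed step between them.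

Compound 3 `Cc1cc(=O)oc2c(CN3CCc4ccccc4C3)c(OC(=O)c3ccccc3)ccc12` is compound 1 with benzoyl in place of hydrogen on an oxygen on an aromatic ring. Among the compounds with values here, no measured pair carries this change, so its effect in this assay is open. The step from compound 1 to compound 3 is expected to be an at least 1.4-fold lower number from compound 1 to compound 3 (0.15 log units; that floor lies within the scatter), a shift toward slightly higher toxicity in this test that may still fall within the scatter; the starting point being a limit, even this direction is uncertain. Compound 3 is accordingly estimated at 70000 nM in this assay, within 25000 nM to 150000 nM, with a real chance that the test again reports only a limit.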

Compound 3, half-maximal cytotoxic concentration: > 100000 nM
Compound 3: only a limit was reported; the forecaster's own chance of this, stated with the estimate: 40%; at least 1.4-fold (0.15 log units) between middle value and limit.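

In this assay compound 3 gives > 100000 nM, a limit of the test and not a number. Within the data shown here, compound 1 is also reported only as a limit, so no step between compound 1 and compound 3 can be read. From the compounds shown here alone, whether benzoyl in place of hydrogen on an oxygen on an aromatic ring changes the cytotoxic concentration at all, and by how much, remains open.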